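Methyl for Hydrogen on the Urea Nitrogen of an Aziridine Nitrile

A few compounds are considered here, and "the series" means these few. Any claim that something is new, unique, unknown or untested is made for them only; others in the source may bear on it.

The measured compounds:
Compound 1 `CC(C)(C)NC(=O)N1CC1C#N`, 132000 nM
Compound 2 `N#CC1CN1C(=O)Nc1ccccc1`, 1200 nM
Compound 3 `N#CC1CN1C(N)=O`, > 90000 nM

Three compounds share the core of compound 3 and differ only in what sits on the amide-type nitrogen of the urea. In a functional assay on L1210 cells (Mus musculus) for inhibition, read by MTT assay (a lower number here means a stronger inhibitor, a higher number a weaker inhibitor), compound 2 gives 1200 nM. In this assay compound 1 gives 132000 nM. For compound 3 this assay reports only a limit, > 90000 nM, and not a number; it is the limit of the limit of > 90000 nM in this assay, at which 1 of the 3 values shown sits. Because of that limit the step that the limit leaves unreadable from compound 1 to compound 3 cannot be read in size, so compound 3 stands at the weak end of what is shown, without a fixed place.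

Compound 4 `CNC(=O)N1CC1C#N` is not yet measured. It differs from compound 3 by methyl in place of hydrogen on an amide-type nitrogen. For the measured compounds named here, the only measured step on this nitrogen that goes between hydrogen and an alkyl group is a step that the limit leaves unreadable from compound 1 to compound 3, which the limit leaves unreadable, so no measured step gives a size for a methyl here. Compound 1 with its tert-butyl gives 132000 nM, and that is the nearest guide to a small alkyl group on this nitrogen. Compound 4 is therefore expected to remain weak in this assay, with an estimated value of 100000 nM, between 20000 nM and 300000 nM, and an expected step that the limit leaves unreadable from compound 3 to compound 4 that may well stay hidden behind a limit.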

Compound 4, half-maximal inhibitory concentration: 8700 nM
Compound 4: the middle estimate sits 11-fold (1.06 log units) above what was measured, and the stated range ends above it.
By their numbers in this assay, from the lowest: compound 2; then compound 4; then compound 1.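

In this assay the step of an at least 10-fold lower number from compound 3 to compound 4 (1.01 log units; beyond the scatter) shows that a single methyl on this amide-type nitrogen is enough to give a clear gain over the unsubstituted urea. The step of a 15-fold lower number from compound 1 to compound 4 (1.18 log units; beyond the scatter) shows that alkyl groups on this nitrogen are not interchangeable, and that the tert-butyl of compound 1 does not stand for methyl here. The first of these steps gives only a minimum size, because compound 3 carries a limit and not a number: the limit of > 90000 nM in this assay, at which 1 of the 4 values shown sits.

The compounds shown leave open where a longer chain, such as ethyl or propyl, would fall on this nitrogen, on the way from methyl to tert-butyl. They also leave open whether an amine or a carboxylic acid at the end of such a chain would keep the number of compound 4.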